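The source may hold more compounds than are shown below. What is called first, only, known or untested is meant among the compounds shown, and "the series" means these compounds.

Working notes on the series.

Compound 1 `CCCCC(O)c1cccc(NC(=O)CCCCl)c1` carries a hydroxy group on a saturated chain carbon and a (3-chloropropyl)carbonyl amide. In a functional assay on M21 cells (Homo sapiens) for antiproliferative activity, with a stated time of 48 h (on this read-out lower numbers stand for stronger inhibition and higher numbers for weaker inhibition), compound 1 gives > 100000 nM, which is a limit of the assay and not a number. Compound 2 `CCCCC(OC)c1cccc(NC(=O)CCCCl)c1` is its methyl ether, the difference being (methyl in place of hydrogen on an oxygen on a saturated carbon). In this assay compound 2 gives > 100000 nM, again a limit and not a number. The step that the two limits leave unreadable from compound 1 to compound 2 because of the limit of > 100000 nM in this assay, at which 2 of the 3 values shown sit.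

Compound 3 `C=CC(=O)Nc1cccc(C(O)CCCC)c1` keeps the hydroxy group but sits on a different core; the two cores differ by vinyl in place of 3-chloropropyl on a carbonyl carbon. In this assay, among the measured compounds shown here, compound 3 gives 98000 nM, the only number in the set. The step of an at least 1.0-fold lower number from compound 1 to compound 3 (0.00 log units; that floor lies within the scatter).

Compound 4 `C=CC(=O)Nc1cccc(C(CCCC)OC)c1` has not been measured. For the measured compounds named here, it differs from compound 3 by methyl in place of hydrogen on an oxygen on a saturated carbon, which is the same change as the one from compound 1 to compound 2, at the same place on both cores: an oxygen on a saturated carbon whose other neighbour is a saturated chain carbon. The earlier instance of the change, a step that the two limits leave unreadable from compound 1 to compound 2, leaves its size unreadable, so it offers no direction for the new pair. The expectation for compound 4 therefore rests mainly on compound 3 at 98000 nM, with the step of a 1.1-fold higher number from compound 3 to compound 4 (0.05 log units; within the scatter) expected to stay small. Compound 4 is estimated at 110000 nM, with a range from 40000 nM to 300000 nM, and a limit rather than a number is a real possibility in this assay.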

Compound 4, half-maximal inhibitory concentration: 48000 nM
The estimate for compound 4 lay 2.3-fold (0.36 log units) above the measured number, within the range that was stated.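

On the core of compound 3, methyl in place of hydrogen on an oxygen on a saturated carbon gives a 2.0-fold lower number from compound 3 to compound 4 (0.31 log units; beyond the scatter) in this assay, whereas the same change on the core of compound 1 cannot be read, so this single readable instance gives no size to compare it with. Vinyl in place of 3-chloropropyl on a carbonyl carbon gives an at least 2.0-fold lower number from compound 2 to compound 4 (0.31 log units; beyond the scatter) in the methoxy pair, and set beside the hydroxy pair, it reads: the same change on two cores in this assay, an at least 1.0-fold lower number (0.00 log units; that floor lies within the scatter) from compound 1 to compound 3 and an at least 2.0-fold lower number (0.31 log units; beyond the scatter) from compound 2 to compound 4; the limit leaves it open whether they differ. Both steps therefore point no higher on the vinyl core, but they do not show that the change carries over with the same size from one core to the other, since compound 1 and compound 2 each stand at a limit and not a number: the limit of > 100000 nM in this assay, at which 2 of the 4 values shown sit.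

Still open, going by these compounds, is whether the hydroxy-to-methoxy step on the core of compound 3 extends to a larger group on that oxygen, such as ethyl or benzyl, or to an amine in place of the hydroxy group. Also open, on these data alone, is how a longer chain on the saturated carbon would read in this assay on either core.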